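Ring contraction at the amine-bearing carbon of compound 3

The source may report more compounds than this note shows. Statements on the series, on what has been measured and on what is new or still open speak of the compounds shown alone.

Measured compounds:
compound 1 `Clc1ccc(C(CCN2CC=C(Cc3ccccc3)CC2)N2CCCC2)cc1Cl` gives 291 nM
compound 2 `CN(C)CCC(c1cc2ccccc2s1)N1CCCC1` gives 863 nM
compound 3 `CN(C)CCC(c1ccc(Cl)c(Cl)c1)N1CCCCC1` gives 602 nM

In an assay on HEK293 cells for inhibition of sodium-dependent dopamine transporter (Homo sapiens), read by scintillation counting (on this read-out lower numbers stand for stronger inhibition and higher numbers for weaker inhibition), compound 3 gives 602 nM. Its number lies within the scatter of that of compound 2, which gives 863 nM, so no order between these two can be read. Going by the values given here, compound 1, which gives 291 nM, stands beyond the scatter at a lower number than compound 3, and is the only measured compound that differs from compound 3 in that way.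

Compound 4 `CN(C)CCC(c1ccc(Cl)c(Cl)c1)N1CCCC1` has not yet been measured. It differs from compound 3 in one place: pyrrolidin-1-yl in place of piperidin-1-yl on a saturated chain carbon bound to an aromatic carbon and a saturated chain carbon. Among the compounds with values here, no pair of measured compounds differs in this way alone, so the size of the step cannot be read from existing data. Compound 1 also carries pyrrolidin-1-yl on its chain carbon, but it differs from compound 3 elsewhere as well, so its lower number in this assay cannot be assigned to the ring alone.

The writer expects a small step from compound 3 to compound 4 in this assay, not clearly beyond the scatter, leaning toward a slightly lower number, as a 1.3-fold lower number from compound 3 to compound 4 (0.13 log units; within the scatter). The estimate for compound 4 is 450 nM, with a range from 200 nM to 1100 nM.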

Compound 4, half-maximal inhibitory concentration: 357 nM
Compound 4: the middle estimate sits 1.3-fold (0.10 log units) above what was measured, within the range that was stated.
By their numbers in this assay, from the lowest: compounds 1, 4, 3 and 2 (each within the scatter of the next, the first and the last beyond it).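

In this assay the exchange of piperidin-1-yl for pyrrolidin-1-yl on a saturated chain carbon bound to an aromatic carbon and a saturated chain carbon now has a size of its own: a 1.7-fold lower number from compound 3 to compound 4 (0.23 log units; within the scatter). Earlier, this change could be seen only together with other differences, whereas this pair isolates it and shows that the ring exchange alone gives no readable order between the two compounds. Nothing in the data given bears on why the two rings read alike.

Left open is whether azetidin-1-yl or morpholin-4-yl on the same chain carbon would also stay within the scatter of compound 4. As far as these compounds go, a single pair carries this step, so whether it holds on the core of compound 1 or compound 2 also remains open.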